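The source may report more compounds than this note shows. Statements on the series, on what has been measured and on what is new or still open speak of the compounds shown alone.

Working notes on the series. For the measured compounds named here, in a functional assay on HeLa cells (Homo sapiens) for antiproliferative activity, read by MTT assay, with a stated time of 48 h (on this read-out lower numbers stand for stronger inhibition and higher numbers for weaker inhibition), compound 1 (`COc1cccc(-c2nn(-c3ccccc3)cc2C(Nc2nc3ccccc3s2)c2c(O)ccc3ccccc23)c1`) gives 14900 nM and compound 2 (`COc1ccc(-c2nn(-c3ccccc3)cc2C(Nc2nc3ccccc3s2)c2c(O)ccc3ccccc23)cc1`) gives 9340 nM as the only numbers so far. These two values lie within the scatter of each other, so compound 2 holds no separate rank from compound 1.

Compound 3 (`Oc1ccc2ccccc2c1C(Nc1nc2ccccc2s1)c1cn(-c2ccccc2)nc1-c1ccc(I)cc1`) is still unmeasured. iodo in place of methoxy on an aromatic carbon describes its change from compound 2: iodo in place of methoxy on an aromatic carbon, para to a large group, or 4-methoxyphenyl to 4-iodophenyl.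

Going by the values given here, the only measured step is a 1.6-fold lower number from compound 1 to compound 2 (0.20 log units; within the scatter) and it bears on this change only indirectly, as it swaps 3-methoxyphenyl for 4-methoxyphenyl and removes no methoxy. Among the compounds with values here, no measured step shows what replacing the methoxy does, so the data give no direction. With that single step as the guide, no shift beyond the scatter is expected in this assay for now, though the uncertainty is wide. The estimate for compound 3 is 9000 nM with an expected range from 3500 nM to 23000 nM on this read-out. The step is expected to be a 1.0-fold lower number from compound 2 to compound 3 (0.02 log units; within the scatter).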

Compound 3, half-maximal inhibitory concentration: 6590 nM
The estimate for compound 3 lay 1.4-fold (0.14 log units) above the measured number; the range from low to high includes it.
By their numbers in this assay, from the lowest: compounds 3, 2 and 1 (each within the scatter of the next, the first and the last beyond it).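

In this assay, for the compounds shown here, the first exchange of the methoxy itself, on an aromatic carbon para to a large group, is read as a 1.4-fold lower number from compound 2 to compound 3 (0.15 log units; within the scatter) and so gives no separable difference between the 4-methoxyphenyl and the 4-iodophenyl. The methoxy is therefore not required at this position for a number in this range, at least where iodo takes its place. The series also now holds its first step beyond the scatter, a 2.3-fold lower number from compound 1 to compound 3 (0.35 log units; beyond the scatter), which is modest in size and joins the 3-methoxyphenyl of one end to the 4-iodophenyl of the other, while compound 2 stays within the scatter of both; no measurement here bears on what lies behind these numbers.

The compounds shown leave open whether an amine, a carboxylic acid or a longer chain such as butoxy on this same aromatic carbon would give a step beyond the scatter from compound 2, and how a 3-iodophenyl would read against the 3-methoxyphenyl of compound 1. They also say nothing about changes elsewhere on the shared core, which stays the same throughout.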